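The compounds below may be only part of what the source reports. "The series", "measured", "known", "first", "only" and "open" are said of these compounds alone.

In an ADME assay on microsomes from liver (Mus musculus, strain CD1) for metabolic stability, read by LC-MS, with a stated time of 1 h (on this read-out lower numbers stand for a less stable compound and higher numbers for a more stable compound), compound 1 (`O=[N+]([O-])c1cn2c(n1)OC[C@@H](OCc1ccc(-c3ccc(F)cc3)cc1)C2`) gives 55% and compound 2 (`COc1cccc(F)c1-c1ccc(CO[C@@H]2COc3nc([N+](=O)[O-])cn3C2)cc1`) gives 0%, the lower of the two numbers. Among the measured compounds shown here, the only measured step is a number 55 percentage points lower from compound 1 to compound 2 (beyond the scatter), with 2-fluoro-6-methoxyphenyl in place of 4-fluorophenyl on an aromatic carbon. Compound 3 (`COc1ccc(-c2ccc(CO[C@@H]3COc4nc([N+](=O)[O-])cn4C3)cc2)cc1F`) has the same atoms as compound 2, joined differently: 3-fluoro-4-methoxyphenyl replaces 2-fluoro-6-methoxyphenyl, para to a large group (3-fluoro-4-methoxyphenyl in place of 2-fluoro-6-methoxyphenyl on an aromatic carbon). The data do not show which feature of the incoming group went with the large drop, so that single step bears on this change only loosely. It does show that a swap at this place can move the number by a wide margin, and compound 2 at 0% leaves room mainly for a rise. The expected change is a number 25 percentage points higher from compound 2 to compound 3 (beyond the scatter), a moderate but uncertain gain. Compound 3 is estimated at 25%, with an expected range from 3% to 58%.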

Compound 3, percent of the compound remaining: 50%
Beside the measured number, compound 3's estimate is 25 percentage points below it, within the range that was stated.
By their numbers in this assay, from the lowest: compound 2; then compounds 3 and 1 (each within the scatter of the next).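

In this assay, the 2-fluoro-6-methoxyphenyl and 3-fluoro-4-methoxyphenyl groups have the same atoms, yet exchanging them gives a number 50 percentage points higher from compound 2 to compound 3 (beyond the scatter), so the earlier drop cannot be tied to the mere presence of a fluorine and a methoxy group on this ring; how they are arranged matters here. Set against the 4-fluorophenyl group, the 3-fluoro-4-methoxyphenyl group gives a number 5 percentage points lower from compound 1 to compound 3 (within the scatter), which shows that a methoxy group at this place can go with a number much like that of the simpler group. Nothing available explains why the arrangement matters.

The three compounds do not separate the part played by the fluorine from that of the methoxy group within the 2-fluoro-6-methoxyphenyl group. On these data alone, how an amine or a carboxylic acid on this ring would read also remains open.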